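Taking the chloro group off compound 2

The compounds below may be only part of what the source reports. "The series", "measured", "known", "first", "only" and "open" are said of these compounds alone.

Among the measured compounds shown here, in a functional assay on HL-60 cells (Homo sapiens) for cytotoxicity, read by luminescence and CellTiter-Glo, with a stated time of 3 days (a higher number here means a weaker inhibitor, a lower number a stronger inhibitor), compound 2 (`N#Cc1ccc(NC(=O)c2cc(Cl)ccc2O)cc1`) gives 700 nM, the lower of the two numbers measured so far, while compound 1 (`N#Cc1ccc(NC(=O)c2cc(-c3ccncc3)ccc2O)cc1`) gives 5410 nM. Compound 3 (`N#Cc1ccc(NC(=O)c2ccccc2O)cc1`) has not yet been measured. It carries hydrogen in place of chloro on an aromatic carbon. For the measured compounds named here, one measured step bears on this change, a 7.7-fold lower number from compound 1 to compound 2 (0.89 log units; beyond the scatter), with chloro in place of pyridin-4-yl. That step is modest but beyond the scatter. Neither compound 1 nor compound 2 carries hydrogen on this carbon, so the direction of the new step is uncertain. Chloro holds the lower number so far, and a moderate loss on removing it is the working expectation. Expected in this assay is a 2.9-fold higher number from compound 2 to compound 3 (0.46 log units; beyond the scatter), smaller than the measured step. For compound 3 the estimated value is 2000 nM, with an expected range of 700 nM to 6000 nM.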

Compound 3, half-maximal inhibitory concentration: 4620 nM
The estimate for compound 3 lay 2.3-fold (0.36 log units) below the measured number; the measured number falls inside the stated range.
By their numbers in this assay, from the lowest: compound 2; then compounds 3 and 1 (each within the scatter of the next).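

Within this assay hydrogen now gives a reference for this carbon, para to a hydroxy group, and taking off chloro gives a 6.6-fold higher number from compound 2 to compound 3 (0.82 log units; beyond the scatter) on the shared core. Replacing pyridin-4-yl with hydrogen gives a 1.2-fold lower number from compound 1 to compound 3 (0.07 log units; within the scatter) and stays within the scatter, so the earlier step from compound 1 to compound 2 reflects a lower number with chloro, not a higher number with pyridin-4-yl. No measurement here accounts for the difference between chloro and hydrogen.

Among the three groups shown, only chloro separates from the others, so one substituent carries the whole effect at this carbon. On these data alone, whether fluoro, bromo, methyl or methoxy on the same carbon would track compound 2 or compound 3 remains open.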